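A few compounds are considered here, and "the series" means these few. Any claim that something is new, unique, unknown or untested is made for them only; others in the source may bear on it.

Measured so far: compound 1 `O=C1/C(=C/c2ccccc2)CCC/C1=C\c1ccc([N+](=O)[O-])cc1` gives 9800 nM in a functional assay on L1210 cells (Mus musculus) for cytotoxicity, with a stated time of 48 h; on this read-out lower numbers stand for stronger inhibition and higher numbers for weaker inhibition; compound 2 `O=C1/C(=C/c2ccc(F)cc2)CCC/C1=C\c1cccc([N+](=O)[O-])c1` gives 16300 nM in the same assay.

Compound 2 sits alongside compound 1 on these numbers: the gap between them is within the scatter, so neither can be set apart from the other. Compound 3 `O=C1/C(=C/c2ccc(Cl)cc2)CCC/C1=C\c1cccc([N+](=O)[O-])c1` has not yet been measured. It differs from compound 2 by chloro in place of fluoro on an aromatic carbon. Within the data shown here, no measured pair shows this change, so no step size is known. The expected step is a 1.4-fold lower number from compound 2 to compound 3 (0.13 log units; within the scatter), not beyond the scatter in either direction. Compound 3 is estimated at 12000 nM, within 5000 nM to 30000 nM.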

Compound 3, half-maximal inhibitory concentration: 9160 nM
For compound 3 the middle estimate is 1.3-fold (0.12 log units) above the measured one, within the range that was stated.
By their numbers in this assay, from the lowest: compounds 3, 1 and 2 (each within the scatter of the next).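

This is the only pair shown that differs in one place, and it gives the first reading of the 4-fluorophenyl to 4-chlorophenyl change: in this assay, chloro in place of fluoro gives a 1.8-fold lower number from compound 2 to compound 3 (0.25 log units; within the scatter). On this single pair, the two groups cannot be told apart at this aromatic carbon on this read-out. No evidence is available that bears on this result.

The compounds shown leave open whether an amine or a carboxylic acid on this carbon would stand clear of the scatter. They also leave open whether chloro and fluoro would stay indistinguishable on a core carrying no nitro group.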